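Replacing the cyano group on the shared core

The source may report more compounds than this note shows. Statements on the series, on what has been measured and on what is new or still open speak of the compounds shown alone.

Compound 1 `COc1c(N2CCN(CC#N)C(C)C2)c(F)cc2c(=O)c(C(=O)O)cn(C3CC3)c12` gives 354 ug/mL in an ADME assay on Vero cells (Chlorocebus sabaeus) for cytotoxicity, read by MTT assay, with a stated time of 72 h (a higher number here means that more compound is tolerated, a lower number that less compound is tolerated), the lowest of the two numbers available. Among the measured compounds shown here, compound 2 `COc1c(N2CCN(CCC#N)C(C)C2)c(F)cc2c(=O)c(C(=O)O)cn(C3CC3)c12` gives 500 ug/mL in this assay, and the one measured step, a 1.4-fold higher number from compound 1 to compound 2 (0.15 log units; within the scatter), lies within the scatter. Compound 3 `COc1c(N2CCN(C/C(C)=N/NC(N)=O)C(C)C2)c(F)cc2c(=O)c(C(=O)O)cn(C3CC3)c12` differs from compound 1 by a group of 7 heavy atoms (3 carbon, 3 nitrogen, 1 oxygen; no ring) in place of a group of 2 heavy atoms (1 carbon, 1 nitrogen; no ring), on a saturated chain carbon bound to an amine nitrogen in a ring. The measured step extended the same chain by one carbon and changed little, but it says nothing about a group of this size and composition. Compound 3 is therefore expected to stay close to compound 1, with a 1.1-fold higher number from compound 1 to compound 3 (0.05 log units; within the scatter). The estimate for compound 3 is 400 ug/mL, ranging from 220 ug/mL to 700 ug/mL.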

Compound 3, half-maximal cytotoxic concentration: 500 ug/mL
For compound 3 the middle estimate is 1.3-fold (0.10 log units) below the measured one; measured number inside the range.
By their numbers in this assay, from the lowest: compounds 1, 2 and 3 (each within the scatter of the next).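

Compound 3 carries a group of 7 heavy atoms with 2 hydrogen-bond donors on the saturated chain carbon bound to an amine nitrogen in a ring, and it gives a 1.4-fold higher number from compound 1 to compound 3 (0.15 log units; within the scatter) and no change at the digits printed from compound 2 to compound 3 (within the scatter) in this assay on the shared core. The earlier compounds shown here showed only cyano and cyanomethyl at this place, whereas compound 3 shows that a larger group without a nitrile stays within the scatter of both.

As far as these compounds go, whether an amine, a carboxylic acid or a group holding a ring would also stay within that scatter here remains open. Nothing available explains this result.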